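Adding to the Ring Group of Compound 2

The source may hold more compounds than are shown below. What is called first, only, known or untested is meant among the compounds shown, and "the series" means these compounds.

Compound 1 `CC(C)C(Nc1nc(Cl)nc2c1ncn2[C@H]1[C@H](O)[C@H](O)[C@]2(CO)C[C@H]12)C(C)C`: > 100000 nM
Compound 2 `O[C@@H]1[C@H](O)[C@@H]2C[C@@H]2[C@H]1n1cnc2c(NC(C3CCC3)C3CCC3)nc(Cl)nc21`: 17000 nM

Within the data shown here, in an ADME assay on Vero 76 cells (Chlorocebus sabaeus) for cytotoxicity, read by neutral red uptake (on this read-out higher numbers stand for lower toxicity in this test and lower numbers for higher toxicity in this test), compound 2 gives 17000 nM, the only actual number so far. Compound 1 gives > 100000 nM, which is a limit of the assay. Compound 3 `OC[C@@]12C[C@@H]1[C@@H](n1cnc3c(NC(C4CCC4)C4CCC4)nc(Cl)nc31)[C@H](O)[C@@H]2O` differs from compound 2 on an aromatic nitrogen: a group of 10 heavy atoms (7 carbon, 3 oxygen; one three-membered non-aromatic ring of carbon only, one five-membered non-aromatic ring of carbon only) in place of a group of 8 heavy atoms (6 carbon, 2 oxygen; one three-membered non-aromatic ring of carbon only, one five-membered non-aromatic ring of carbon only), on an aromatic nitrogen. Among the measured compounds shown here, the group entering compound 3 also stands in compound 1, and no measured pair isolates this change. With that single guide, a rise beyond the scatter is expected in this assay, towards lower toxicity. The estimated change is a 2.1-fold higher number from compound 2 to compound 3 (0.31 log units; beyond the scatter). For compound 3 the expected value is 35000 nM, within an estimated range of 12000 nM to 100000 nM.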

Compound 3, half-maximal cytotoxic concentration: 28000 nM
Compound 3: middle estimate off by 1.3-fold (0.10 log units), on the high side; measured number inside the range.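

Placing the group of 10 heavy atoms on the aromatic nitrogen, instead of the group of 8, gives a 1.6-fold higher number from compound 2 to compound 3 (0.22 log units; within the scatter), so this swap does not separate the two compounds. Dicyclobutylmethyl in place of 1-isopropyl-2-methylpropyl gives an at least 3.5-fold lower number from compound 1 to compound 3 (0.55 log units; beyond the scatter), a change that does exceed the scatter. That size is only a minimum, because compound 1 stands at a limit: the limit of > 100000 nM in this assay, at which 1 of the 3 values shown sits.

The compounds shown leave open how the number would respond to an amine or a carboxylic acid on this ring group.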